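Triazole N-aryl variation across the spiro-fused series

This account rests on a few compounds, and the source may have more. Where it says the series, first, only, none or still open, it means among the compounds named here.

Compound 3 `N#CC1=C(N)Oc2c(N)cc3nc4ccccc4nc3c2C12C(=O)N(Cc1cnnn1-c1ccc([N+](=O)[O-])cc1[N+](=O)[O-])c1ccccc12` gives 20900 nM in a functional assay on MCF7 cells (Homo sapiens) for antiproliferative activity, read by MTT assay, with a stated time of 48 h (on this read-out higher numbers stand for weaker inhibition and lower numbers for stronger inhibition), the lowest of the two numbers on hand. Its nearest neighbour is compound 1 `N#CC1=C(N)Oc2c(N)cc3nc4ccccc4nc3c2C12C(=O)N(Cc1cnnn1-c1ccccc1Cl)c1ccccc12`, which in this assay gives 34400 nM; the step of a 1.6-fold lower number from compound 1 to compound 3 (0.22 log units; within the scatter) stays within the scatter. Compound 2 `Cc1ccc(-n2nncc2CN2C(=O)C3(C(C#N)=C(N)Oc4c(N)cc5nc6ccccc6nc5c43)c3ccccc32)cc1C` reaches only a limit in this assay, > 50000 nM. From that limit the step of an at least 2.3-fold lower number from compound 2 to compound 3 (0.37 log units; beyond the scatter), while an at least 1.4-fold higher number from compound 1 to compound 2 (0.16 log units; that floor lies within the scatter). The aryl swaps measured so far therefore moved this assay little, the dinitro case being the only one to clear the scatter.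

Compound 4 `COc1cc(-n2nncc2CN2C(=O)C3(C(C#N)=C(N)Oc4c(N)cc5nc6ccccc6nc5c43)c3ccccc32)c(OC)cc1Cl` carries the change (4-chloro-2,5-dimethoxyphenyl in place of 2,4-dinitrophenyl on an aromatic nitrogen). The steps from compound 1 and compound 2 to compound 3 bear on it; both point to a modest rise at most once the 2,4-dinitrophenyl leaves. Compound 4 is expected at 32000 nM, within 13000 nM to 80000 nM. That estimate means the step of a 1.5-fold higher number from compound 3 to compound 4 (0.19 log units; within the scatter), expected to be small and upward.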

Compound 4, half-maximal inhibitory concentration: > 50000 nM
Compound 4: a limit, no number; the forecaster's own chance of this, stated with the estimate: 25%; at least 1.5-fold (0.19 log units) between middle value and limit.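

In this assay the 2,4-dinitrophenyl group now separates beyond the scatter from a second aryl group on the aromatic nitrogen, the 4-chloro-2,5-dimethoxyphenyl group (an at least 2.3-fold higher number from compound 3 to compound 4 (0.37 log units; beyond the scatter)), so the separation no longer rests on the 3,4-dimethylphenyl case alone. Against the 2-chlorophenyl group no such separation is established (an at least 1.4-fold higher number from compound 1 to compound 4 (0.16 log units; that floor lies within the scatter)), the floor of that step lying within the scatter, and the step between the two limits cannot be read. Compound 2 and compound 4 are both limits rather than numbers: the limit of > 50000 nM in this assay, at which 2 of the 4 values shown sit.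

As far as these compounds go, how far compound 2 and compound 4 actually lie from each other remains open. Also open, from the compounds shown here alone, is what a pyridyl ring, a benzyl group or a short alkyl chain would give on that aromatic nitrogen in place of the substituted phenyl groups.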